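The source may hold more compounds than are shown below. What is called first, only, known or untested is meant among the compounds shown, and "the series" means these compounds.

In a functional assay on DU-145 cells (Homo sapiens) for antiproliferative activity, with a stated time of 48 h (on this read-out lower numbers stand for higher toxicity in this test and higher numbers for lower toxicity in this test), compound 1 `Cc1cc(O)c(C2=NN(c3ccc(S(N)(=O)=O)cc3)C(c3ccccc3O)C2)cc1Cl` gives 10600 nM, and compound 2 `Cc1cc(O)c(C2=NN(c3ccc(S(N)(=O)=O)cc3)C(c3ccccc3Cl)C2)cc1Cl` gives 7350 nM. Compound 2 sits at the low end of the two numbers, though the separation, a 1.4-fold lower number from compound 1 to compound 2 (0.16 log units; within the scatter), is within the scatter. Compound 3 `Cc1cc(O)c(C2=NN(c3ccc(S(N)(=O)=O)cc3)C(/C=C/c3ccccc3)C2)cc1Cl` differs from compound 2 by 2-phenylethenyl in place of 2-chlorophenyl on a saturated ring carbon. Going by the values given here, the single measured step touches another part of the structure and was small, so no measured step speaks directly to this change. The step expected for compound 3 is a 1.1-fold lower number from compound 2 to compound 3 (0.02 log units; within the scatter), nothing beyond the scatter. The estimated value for compound 3 is 7000 nM, within a range from 2500 nM to 20000 nM.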

Compound 3, concentration lethal to 50% of the cells: > 100000 nM
Compound 3 ended at the assay's limit (the forecaster's own chance of this, stated with the estimate: 5%); at least 14-fold (1.15 log units) between middle value and limit.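

At the saturated ring carbon next to the ring nitrogen, replacing the substituted phenyl with 2-phenylethenyl moves the read-out sharply in this assay: the change gives an at least 13-fold higher number from compound 2 to compound 3 (1.13 log units; beyond the scatter), and an at least 9.4-fold higher number from compound 1 to compound 3 (0.97 log units; beyond the scatter). The earlier pair, changed only on the aromatic ring at this position, showed no step beyond the scatter. Compound 3 stands at a limit of the assay, not at a number: the limit of > 100000 nM in this assay, at which 1 of the 3 values shown sits.

From the compounds shown here alone, whether the double bond or the longer link to the phenyl ring drives this remains open. Going by these compounds, how a saturated 2-phenylethyl chain or an amine at this carbon would read also remains open.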